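Alkynyl aryl series: pyridin-3-yl in place of 4-chlorophenyl

This account rests on a few compounds, and the source may have more. Where it says the series, first, only, none or still open, it means among the compounds named here.

Measured so far in an assay on CHO cells for displacement of a labelled ligand from prostaglandin D2 receptor 2 (Homo sapiens), read by scintillation counting; on this read-out higher numbers stand for weaker inhibition and lower numbers for stronger inhibition:
compound 1 `O=C(O)COc1ccc(Cl)cc1C#Cc1ccc(Cl)s1` gives 183 nM
compound 2 `Cn1ccnc1C#Cc1cc(Cl)ccc1OCC(=O)O` gives 1470 nM
compound 3 `O=C(O)COc1ccc(Cl)cc1C#Cc1ccc(Cl)cc1` gives 60 nM

Compound 3 stands lowest of the three: a 3.1-fold lower number from compound 1 to compound 3 (0.48 log units; beyond the scatter) and a 25-fold lower number from compound 2 to compound 3 (1.39 log units; beyond the scatter), both beyond the scatter. Compound 4 `O=C(O)COc1ccc(Cl)cc1C#Cc1cccnc1` is the next variation; (pyridin-3-yl in place of 4-chlorophenyl on a triple-bonded carbon). The two steps into compound 3 bear on it, since each puts a heteroaryl group on the same triple-bonded carbon in place of 4-chlorophenyl: the five-membered chlorinated ring cost a modest amount, the five-membered ring with a hydrogen-bond acceptor a large amount. Pyridin-3-yl keeps a six-membered ring but drops the chlorine and adds one acceptor, so a higher number is expected in this assay, between those two outcomes, a 5.0-fold higher number from compound 3 to compound 4 (0.70 log units; beyond the scatter). Compound 4 is estimated at 300 nM, within 100 nM to 1000 nM.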

Compound 4, inhibition constant: 117 nM
For compound 4 the middle estimate is 2.6-fold (0.41 log units) above the measured one; low and high end bracket the measured number.
By their numbers in this assay, from the lowest: compounds 3, 4 and 1 (each within the scatter of the next, the first and the last beyond it); then compound 2.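

At this triple-bonded carbon, pyridin-3-yl replaces 4-chlorophenyl in this assay with a 2.0-fold higher number from compound 3 to compound 4 (0.29 log units; within the scatter), so neither the chlorine nor the all-carbon ring is shown to be needed here. Replacing 5-chlorothiophen-2-yl gives a 1.6-fold lower number from compound 1 to compound 4 (0.19 log units; within the scatter), whereas replacing 1-methyl-1H-imidazol-2-yl gives a 13-fold lower number from compound 2 to compound 4 (1.10 log units; beyond the scatter), so a ring acceptor alone does not set the large step. No measurement at hand accounts for these steps. Still open, on these data alone, is how pyridin-2-yl or pyridin-4-yl would compare, and whether a chlorine or an amine on the pyridin-3-yl ring would shift the number.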